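The source may hold more compounds than are shown below. What is called first, only, known or untested is meant among the compounds shown, and "the series" means these compounds.

Compound 1 `O=C(Nc1ccccn1)c1c(O)c2cccnc2n(-c2ccccc2)c1=O` gives -13.5%. Compound 2 `O=C(Nc1ccc(Cl)cc1)c1c(O)c2cccnc2n(-c2ccccc2)c1=O` gives 11.6%. Compound 3 `O=C(Nc1ccncc1)c1c(O)c2cccnc2n(-c2ccccc2)c1=O` gives 34.9%.

In a functional assay on the whole organism for inhibition, with Rattus norvegicus as the target, read by paw edema, at a dose of 100 mg/kg by the oral route (a lower number here means less inhibition, a higher number more inhibition at the dose given (going by the name of the read-out)), compound 3 stands highest of the three measured values, ahead of compound 2 by a number 23.3 percentage points higher from compound 2 to compound 3 (beyond the scatter) and ahead of compound 1 by a number 48.4 percentage points higher from compound 1 to compound 3 (beyond the scatter). Compound 4 `O=C(Nc1nccs1)c1c(O)c2cccnc2n(-c2ccccc2)c1=O` differs from compound 3 in one place: 1,3-thiazol-2-yl in place of pyridin-4-yl on an amide-type nitrogen. Among the measured compounds shown here, no measured step covers this exact change, but both steps into compound 3 show that the group on the amide-type nitrogen moves the read-out well beyond the scatter, and the ring that enters is neither of the groups that gave the highest numbers. A drop is therefore expected, of roughly a number 20.9 percentage points lower from compound 3 to compound 4 (beyond the scatter). For compound 4 the estimate is 14%, with a range from -15% to 40%.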

Compound 4, a percentage reported as inhibition, in the whole organism at one dose (the size of the read-out at that dose, not a potency): 4.6%
The estimate for compound 4 lay 9.4 percentage points above the measured number, within the range that was stated.
By their numbers in this assay, from the lowest: compound 1; then compounds 4 and 2 (each within the scatter of the next); then compound 3.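

In this assay the five-membered 1,3-thiazol-2-yl ring on the amide-type nitrogen does not keep the level of pyridin-4-yl (a number 30.3 percentage points lower from compound 3 to compound 4 (beyond the scatter)), yet it stays clear of pyridin-2-yl (a number 18.1 percentage points higher from compound 1 to compound 4 (beyond the scatter)). Against 4-chlorophenyl it shows no distinguishable difference (a number 7 percentage points lower from compound 2 to compound 4 (within the scatter)), so among these four only pyridin-4-yl stands apart at the top. Nothing measured here bears on why these rings differ. The compounds shown leave open how a benzyl group or a piperidine ring would read on this nitrogen.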